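Carbonyl in Place of Sulfonyl: Expecting Compound 4

A few compounds are considered here, and "the series" means these few. Any claim that something is new, unique, unknown or untested is made for them only; others in the source may bear on it.

Compound 1, `CC(C)=CCC1Cc2c(OCCCNS(=O)(=O)c3ccc(Br)cc3)cc(=O)n(CCCO)c2CC1(C)C`: 19.5%
Compound 2, `CC(C)=CCC/C(C)=C/CC1Cc2c(OCCCNS(=O)(=O)c3ccc(C(F)(F)F)cc3)cc(=O)n(CCCO)c2CC1(C)C`: 26.4%
Compound 3, `CC(C)=CCC/C(C)=C/CC1Cc2c(OCCCNS(=O)(=O)c3ccc(Br)cc3)cc(=O)n(CCCO)c2CC1(C)C`: 15.2%

All three compounds share one core and differ only in their side chains. In a functional assay on PANC-1 cells (Homo sapiens) for inhibition, read by MTT assay, with a stated time of 24 h, tested at 10 uM (on this read-out lower numbers stand for less inhibition and higher numbers for more inhibition at the one concentration tested (going by the name of the read-out)), compound 3 gives 15.2%, the lowest of the three numbers. Compound 1 is nearest: the step of a number 4.3 percentage points lower from compound 1 to compound 3 (within the scatter) lies within the scatter, so the two cannot be told apart. Compound 2 is furthest: the step of a number 11.2 percentage points lower from compound 2 to compound 3 (beyond the scatter) is modest but beyond the scatter.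

Compound 4, `CC(C)=CCC/C(C)=C/CC1Cc2c(OCCCNC(=O)c3ccc([N+](=O)[O-])cc3)cc(=O)n(CCCO)c2CC1(C)C`, differs from compound 3 in one place: (4-nitrophenyl)carbonyl in place of (4-bromophenyl)sulfonyl on an amine nitrogen. Among the measured compounds shown here, only one measured step touches the group on the amine nitrogen, namely a number 11.2 percentage points lower from compound 2 to compound 3 (beyond the scatter), where bromo replaced trifluoromethyl on an aromatic carbon and the number moved modestly. The step of a number 4.3 percentage points lower from compound 1 to compound 3 (within the scatter) concerns the chain on the core and says nothing about this position. For the measured compounds named here, no measured step exchanges a sulfonyl for a carbonyl, and none brings in a nitro group, so the direction remains open. A modest step either way is the most the data support. Compound 4 is therefore expected to give 22%, with a range from 8% to 38%. The step of a number 6.8 percentage points higher from compound 3 to compound 4 (within the scatter) is thus only an estimate, expected to stay near the scatter.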

Compound 4, a percentage reported as inhibition, at one concentration (the size of the read-out at that concentration, not a potency): 16.8%
The estimate for compound 4 lay 5.2 percentage points above the measured number, within the range that was stated.
By their numbers in this assay, from the lowest: compounds 3, 4, 1 and 2 (each within the scatter of the next, the first and the last beyond it).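

In this assay the exchange on the amine nitrogen gives a number 1.6 percentage points higher from compound 3 to compound 4 (within the scatter), so replacing (4-bromophenyl)sulfonyl with (4-nitrophenyl)carbonyl produces no change that can be told from the scatter. The earlier compounds shown here all keep the sulfonyl at this position and vary only the group on the aromatic ring, as in a number 11.2 percentage points lower from compound 2 to compound 3 (beyond the scatter); compound 4 adds the finding that a sulfonyl is not needed for a number of this size, since a carbonyl in its place gives a result that cannot be distinguished from that of compound 3. None of the measurements shown explains why the two compounds read alike.

The exchange alters two things at once, the link to the amine nitrogen and the nitro or bromo group on the aromatic ring, so the compounds shown cannot say what each part does alone, or whether two separate effects happen to cancel. They also leave open how this assay would read with an amine or a carboxylic acid in place of the nitro group, or with a longer chain carrying the amine nitrogen.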